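A Fluoro Swap on Compound 1

The compounds below may be only part of what the source reports. "The series", "measured", "known", "first", "only" and "open" are said of these compounds alone.

In a functional assay on A-431 cells (Homo sapiens) for inhibition, with a stated time of 3 days (a lower number here means a stronger inhibitor, a higher number a weaker inhibitor), compound 1 `COc1ccc(-c2[nH]c3ccccc3c2C=O)cc1` gives 210 nM and compound 2 `COc1ccc(-c2[nH]c3ccc(OC)cc3c2C=O)cc1` gives 200 nM, so the two stand level. Compound 3 `COc1ccc(-c2[nH]c3cc(F)ccc3c2C=O)cc1` differs from compound 1 by one change: fluoro in place of hydrogen on an aromatic carbon. Among the measured compounds shown here, the only measured step, methoxy in place of hydrogen on an aromatic carbon, is a 1.1-fold lower number from compound 1 to compound 2 (0.02 log units; within the scatter). It involves a different group and offers limited guidance, but no shift beyond the scatter is expected in this assay. The expected step is a 1.1-fold lower number from compound 1 to compound 3 (0.04 log units; within the scatter). For compound 3, the estimate is 190 nM, with an expected range of 80 nM to 450 nM.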

Compound 3, half-maximal inhibitory concentration: 180 nM
Beside the measured number, compound 3's estimate is 1.1-fold (0.02 log units) above it, within the range that was stated.
By their numbers in this assay, from the lowest: compounds 3, 2 and 1 (each within the scatter of the next).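

Fluoro in place of hydrogen on this aromatic carbon, meta to a fused ring and para to a fused ring, gives a 1.2-fold lower number from compound 1 to compound 3 (0.07 log units; within the scatter) in this assay. The core of compound 1 therefore accepts this single fluorine atom at this place with no shift beyond the scatter. Nothing measured here offers an explanation for this result. The compounds shown leave open whether an amine, a carboxylic acid or a longer chain on this same carbon would keep the number at this level. They also leave open whether fluoro would do so at other carbons of this ring.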